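Stability outlook for a new group on the carbonyl carbon

The source may report more compounds than this note shows. Statements on the series, on what has been measured and on what is new or still open speak of the compounds shown alone.

In an ADME assay on microsomes from liver (Homo sapiens) for metabolic stability, read by LC-MS, with a stated time of 30 min, tested at 1 uM (on this read-out higher numbers stand for a more stable compound and lower numbers for a less stable compound), compound 1 (`O=C(NCc1ccc(S(=O)(=O)c2cccc(C(F)(F)F)c2)cc1)c1cc2cnccc2[nH]1`) gives 81%, compound 2 (`O=C(NCc1ccc(S(=O)(=O)c2cccc(C(F)(F)F)c2)cc1)c1cc2ccncc2o1`) gives 48% and compound 3 (`O=C(NCc1ccc(S(=O)(=O)c2cccc(C(F)(F)F)c2)cc1)c1cnc2nccn2c1`) gives 41%. Compound 3 therefore stands level with compound 2 and well short of compound 1. Compound 4 (`O=C(NCc1ccc(S(=O)(=O)c2cccc(C(F)(F)F)c2)cc1)c1ccc2nccn2c1`) differs from compound 3 on the carbonyl carbon: a group of 9 heavy atoms (7 carbon, 2 nitrogen; one five-membered aromatic ring with 2 hetero atoms, one six-membered aromatic ring with 1 hetero atom) in place of a group of 9 heavy atoms (6 carbon, 3 nitrogen; one five-membered aromatic ring with 2 hetero atoms, one six-membered aromatic ring with 2 hetero atoms), on a carbonyl carbon. Among the measured compounds shown here, no measured step isolates this change. The large steps, a number 33 percentage points lower from compound 1 to compound 2 (beyond the scatter) and a number 40 percentage points lower from compound 1 to compound 3 (beyond the scatter), both leave the group of compound 1, which compound 4 does not carry. The nearest guide is the small step of a number 7 percentage points lower from compound 2 to compound 3 (within the scatter). The expected step is a number 5 percentage points lower from compound 3 to compound 4 (within the scatter), with nothing beyond the scatter foreseen. For compound 4 the estimated value is 36%, with an expected range of 16% to 58%.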

Compound 4, percent of the compound remaining: 26%
For compound 4 the middle estimate is 10 percentage points above the measured one; the range from low to high includes it.
By their numbers in this assay, from the lowest: compound 4; then compounds 3 and 2 (each within the scatter of the next); then compound 1.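

In this assay a small change on the carbonyl carbon counts: 2 nitrogen in place of 3, with the same ring sizes, gives a number 15 percentage points lower from compound 3 to compound 4 (beyond the scatter) and so exceeds the scatter. The group of compound 4 also sits apart from the other two groups, with a number 22 percentage points lower from compound 2 to compound 4 (beyond the scatter) and a number 55 percentage points lower from compound 1 to compound 4 (beyond the scatter) as the widest step at this place. No measurement at hand accounts for these steps.

From the compounds shown here alone, what remains open is whether a single-ring group on the carbonyl carbon, such as a pyridine or a phenyl carrying an amine, comes near compound 1 or stays near compound 4.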